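Adding a Bromo Group to a Ring Not Yet Varied

This account rests on a few compounds, and the source may have more. Where it says the series, first, only, none or still open, it means among the compounds named here.

Measured in an assay on HEK293 cells for displacement of a labelled ligand from metabotropic glutamate receptor 5 (Rattus norvegicus); a lower number here means a stronger inhibitor, a higher number a weaker inhibitor:
compound 1, `O=C(Nc1cc(-c2ccccc2)nn1-c1ccccc1)c1ccccc1`, 4180 nM
compound 2, `COc1cccc(C(=O)Nc2cc(-c3ccccc3)nn2-c2ccccc2)c1`, 1290 nM
compound 3, `O=C(Nc1cc(-c2ccccc2)nn1-c1ccccc1)c1ccc(Cl)c(Cl)c1`, 160 nM

Compound 1 gives the highest number of the three in this assay. The step of a 3.2-fold lower number from compound 1 to compound 2 (0.51 log units; beyond the scatter) and the step of a 26-fold lower number from compound 1 to compound 3 (1.42 log units; beyond the scatter) both lower the number, and the step of an 8.1-fold lower number from compound 2 to compound 3 (0.91 log units; beyond the scatter) lowers it further. All three of these changes sit on the ring attached to the carbonyl.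

Compound 4, `O=C(Nc1cc(-c2ccccc2)nn1-c1ccccc1Br)c1ccccc1`, differs from compound 1 by bromo in place of hydrogen on an aromatic carbon. Going by the values given here, this change sits on a different ring from the one carrying the earlier changes, ortho to a large group. Among the compounds with values here, none of the measured steps touches that ring, so they bear only indirectly on this change: they show that a single added group can move the number beyond the scatter, but they give no direction for this particular position. The expected step is therefore small, a 1.4-fold lower number from compound 1 to compound 4 (0.14 log units; within the scatter), and compound 4 is estimated at 3000 nM, with a range from 800 nM to 10000 nM.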

Compound 4, inhibition constant: 2600 nM
The estimate for compound 4 lay 1.2-fold (0.06 log units) above the measured number, and the stated range covers the measured number.
By their numbers in this assay, from the lowest: compound 3; then compounds 2, 4 and 1 (each within the scatter of the next, the first and the last beyond it).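

Going by these compounds alone, this is the first change on this ring, and bromo, ortho to a large group, gives a 1.6-fold lower number from compound 1 to compound 4 (0.21 log units; within the scatter) in this assay. The two compounds therefore cannot be told apart, so this place can carry a bromine without the number leaving the usual scatter, whereas changing the ring attached to the carbonyl gave a 26-fold lower number from compound 1 to compound 3 (1.42 log units; beyond the scatter). Nothing available explains why this bromo step is so small.

On these data alone, one group at one place says little about the ring as a whole, so it remains open whether an amine or a carboxylic acid here, or bromo elsewhere on this ring, would move the number beyond the scatter. Also open, as far as these compounds go, is whether this bromo would leave the number just as unchanged when added to compound 3.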